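Adding a nitro group to compound 2

The compounds below may be only part of what the source reports. "The series", "measured", "known", "first", "only" and "open" are said of these compounds alone.

Measured in a functional assay on T98G cells (Homo sapiens) for cytotoxicity, read by MTT assay, with a stated time of 48 h; a lower number here means a stronger inhibitor, a higher number a weaker inhibitor
compound 1 `C/C(=N\NC(=S)Nc1ccccc1F)c1ccccn1` gives 3.1 nM
compound 2 `C/C(=N\NC(=S)Nc1ccccc1)c1ccccn1` gives 6.81 nM

Of these two compounds, compound 2 carries the higher number, which makes it the weaker inhibitor of the pair. The next compound to be tested is compound 3 `C/C(=N\NC(=S)Nc1ccccc1[N+](=O)[O-])c1ccccn1`. It is compound 2 with nitro in place of hydrogen on an aromatic carbon, ortho to a large group (nitro in place of hydrogen on an aromatic carbon).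

Among the compounds with values here, no measured step involves nitro, so the evidence is thin. The closest guide is a 2.2-fold higher number from compound 1 to compound 2 (0.34 log units; beyond the scatter) and this modest step replaces fluoro with hydrogen on an aromatic carbon. Read in reverse, it links a group in place of that hydrogen to a lower number. Nitro is not fluoro, however, so this comparison gives only a weak hint of direction. A modest move towards a lower number seems most likely, but a move the other way cannot be ruled out.

The estimated change is a 1.5-fold lower number from compound 2 to compound 3 (0.18 log units; within the scatter) in this assay and it remains only an expectation. Compound 3 is expected at 4.5 nM within an estimated range from 1.5 nM to 15 nM for now.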

Compound 3, half-maximal inhibitory concentration: 6.61 nM
Compound 3: the middle estimate sits 1.5-fold (0.17 log units) below what was measured; measured number inside the range.
By their numbers in this assay, from the lowest: compound 1; then compounds 3 and 2 (each within the scatter of the next).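

In this assay, nitro in place of hydrogen on an aromatic carbon, ortho to a large group, gives a 1.0-fold lower number from compound 2 to compound 3 (0.01 log units; within the scatter) and so cannot be told apart from hydrogen at this position, even though nitro brings 3 heavy atoms where hydrogen brings none. Replacing fluoro with nitro at the same place gives a 2.1-fold higher number from compound 1 to compound 3 (0.33 log units; beyond the scatter) in this assay, much like the step with hydrogen, a 2.2-fold higher number from compound 1 to compound 2 (0.34 log units; beyond the scatter), so among these three compounds only the fluoro compound stands apart, and putting a group in place of this hydrogen does not by itself lead to a lower number. No measurement shown here accounts for fluoro standing apart from nitro and hydrogen at this position.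

As far as these compounds go, it remains open whether other groups at this position, such as an amine, a chlorine atom or a carboxylic acid, would fall with fluoro or with nitro and hydrogen. From the compounds shown here alone, it is also open whether fluoro would keep its lower number on another carbon of the same six-membered aromatic ring.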